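From iodo to ethynyl: the next step from compound 2

The compounds below may be only part of what the source reports. "The series", "measured", "known", "first", "only" and "open" are said of these compounds alone.

Compound 1 `C#C[C@@]1(O)[C@@H](CO)O[C@@H](n2cnc3c(-c4ccccc4)ncnc32)[C@@H]1O`: > 250000 nM (a limit, not a number)
Compound 2 `C#C[C@@]1(O)[C@@H](CO)O[C@@H](n2cc(I)c3c(N)ncnc32)[C@@H]1O`: 56 nM

Among the measured compounds shown here, in a functional assay on L1210 cells (Mus musculus) for antiproliferative activity, read by cell counting, with a stated time of 48 h (on this read-out lower numbers stand for stronger inhibition and higher numbers for weaker inhibition), compound 2 gives 56 nM, the only actual number so far. Compound 1 reaches only a limit of the assay, > 250000 nM.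

Compound 3 `C#Cc1cn([C@@H]2O[C@H](CO)[C@](O)(C#C)[C@H]2O)c2ncnc(N)c12` has not yet been measured. It carries ethynyl in place of iodo on an aromatic carbon. For the measured compounds named here, no measured pair shows what this swap does, so the expectation is loose: a modest weakening in this assay, possibly none beyond the usual scatter. The expected change is a 2.3-fold higher number from compound 2 to compound 3 (0.37 log units; beyond the scatter). For compound 3 the estimate is 130 nM, with an expected range of 25 nM to 700 nM.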

Compound 3, half-maximal inhibitory concentration: 159000 nM
Estimate against measurement, compound 3: 1200-fold (3.09 log units) below; the measured number lies above the stated range.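

In this assay, this position proves highly sensitive to the group it carries: ethynyl in place of iodo on an aromatic carbon gives a 2800-fold higher number from compound 2 to compound 3 (3.45 log units; beyond the scatter), so a swap of one small group removes nearly all the activity. Compound 1 gives only a limit, not a number, and the weak end of the read-out is now nearly reached: the limit of > 250000 nM in this assay, at which 1 of the 3 values shown sits.

The compounds shown do not tell whether the loss is specific to ethynyl or would follow any replacement of iodo. Bromo, methyl or an amine at this position would help separate the two.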